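The source may report more compounds than this note shows. Statements on the series, on what has been measured and on what is new or still open speak of the compounds shown alone.

Compound 1 `CNC(=O)c1cccc(NC(=O)N2CCC(Oc3ccccc3)CC2)c1`: 370 nM
Compound 2 `CNC(=O)c1cccc(NC(=O)N2CCC(Oc3ccccc3Br)CC2)c1`: < 4 nM, which is a limit of the assay, not a number.
Compound 3 `CNC(=O)c1cccc(NC(=O)N2CCC(Oc3ccccc3OC)CC2)c1`: 81 nM

All three were tested in an assay on isolated protein for inhibition of acyl-CoA desaturase 1 (Mus musculus); on this read-out lower numbers stand for stronger inhibition and higher numbers for weaker inhibition. Among the numbers given, compound 3 has the lowest; compound 1 stands behind it by the step of a 4.6-fold lower number from compound 1 to compound 3 (0.66 log units; beyond the scatter). Compound 4 `CNC(=O)c1cccc(NC(=O)N2CCC(Oc3ccc(F)cc3Cl)CC2)c1` differs from compound 3 by 2-chloro-4-fluorophenyl in place of 2-methoxyphenyl on an oxygen on a saturated carbon. Among the measured compounds shown here, two measured steps bear on this change: an at least 92-fold lower number from compound 1 to compound 2 (1.96 log units; beyond the scatter) and an at least 20-fold higher number from compound 2 to compound 3 (1.30 log units; beyond the scatter), both large, showing that a bromo on this ring gives a far lower number than methoxy. Since compound 4 again carries a halogen where compound 3 carries methoxy, a large step toward lower numbers is expected in this assay, a 10-fold lower number from compound 3 to compound 4 (1.01 log units; beyond the scatter). Compound 4 is therefore estimated at 8 nM, with a range from 2 nM to 40 nM.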

Compound 4, half-maximal inhibitory concentration: 6 nM
For compound 4 the middle estimate is 1.3-fold (0.12 log units) above the measured one; measured number inside the range.
By their numbers in this assay, from the lowest: compound 4; then compound 3; then compound 1. At a limit, below all of these: compound 2.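

In this assay, 2-chloro-4-fluorophenyl on this oxygen gives a lower number than the two other rings measured with a real number. In place of 2-methoxyphenyl it gives a 14-fold lower number from compound 3 to compound 4 (1.13 log units; beyond the scatter), and in place of phenyl it gives a 62-fold lower number from compound 1 to compound 4 (1.79 log units; beyond the scatter). Until now, the low end for a halogen-bearing ring rested only on compound 2, whose value is a limit. In place of 2-bromophenyl, 2-chloro-4-fluorophenyl gives an at least 1.5-fold higher number from compound 2 to compound 4 (0.17 log units; that floor lies within the scatter). This step sets no order between the two rings, because one end of it stands at a limit: the limit of < 4 nM in this assay, at which 1 of the 4 values shown sits.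

From the compounds shown here alone, since chloro and fluoro enter together, the share of each remains open. Also open, going by these compounds, is how a ring carrying an amine or a carboxylic acid would fare here.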